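This account rests on a few compounds, and the source may have more. Where it says the series, first, only, none or still open, it means among the compounds named here.

Measured so far in an assay on membranes from CHO cells for displacement of a labelled ligand from adenosine receptor A1 (Homo sapiens), read by scintillation counting, with a stated time of 60 min, tested at 1 uM; a higher number here means more inhibition at the concentration tested (going by the name of the read-out), a lower number less inhibition:
Compound 1, `CCCOC(=O)C1=C(C)NC(=O)NC1c1cccs1`, gives 43%.
Compound 2, `CCNC(=O)C1=C(C)NC(=O)NC1c1cccs1`, gives 1%.
Compound 3, `CCN(CC)C(=O)C1=C(C)NC(=O)NC1c1cccs1`, gives 13%.

Compound 3 holds the second highest of the three numbers in this assay: compound 2 sits closest, with a number 12 percentage points higher from compound 2 to compound 3 (beyond the scatter), and compound 1 furthest, with a number 30 percentage points lower from compound 1 to compound 3 (beyond the scatter). Compound 4, `CC1=C(C(=O)SC(C)C)C(c2cccs2)NC(=O)N1`, has not yet been measured. The change from compound 3 is isopropylsulfanyl in place of diethylamino on a carbonyl carbon. Among the measured compounds shown here, two measured steps bear on it, both made on a carbonyl carbon: replacing propoxy by diethylamino gave a number 30 percentage points lower from compound 1 to compound 3 (beyond the scatter), and replacing it by ethylamino gave a number 42 percentage points lower from compound 1 to compound 2 (beyond the scatter); within the amide-type pair, a number 12 percentage points higher from compound 2 to compound 3 (beyond the scatter). Isopropylsulfanyl, like propoxy, is not an amide-type nitrogen, so the reversal of the diethylamino step is the nearest guide, while an exact return to the propoxy number cannot be assumed from a single comparison. Compound 4 is therefore expected to run higher than compound 3 in this assay, with an estimated step of a number 22 percentage points higher from compound 3 to compound 4 (beyond the scatter). Compound 4 is estimated at 35%, with an expected range from 15% to 55%.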

Compound 4, a percentage reported as inhibition, at one concentration (the size of the read-out at that concentration, not a potency): 1%
For compound 4 the middle estimate is 34 percentage points above the measured one; measured number outside the range, below it.
By their numbers in this assay, from the lowest: compounds 2 and 4 (each within the scatter of the next); then compound 3; then compound 1.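

Isopropylsulfanyl on the carbonyl carbon does not behave like propoxy in this assay: a number 42 percentage points lower from compound 1 to compound 4 (beyond the scatter), so a group that is not an amide-type nitrogen does not by itself keep the number of compound 1. Among the compounds shown here, the sulfur-linked group also gives no gain over either amide, with a number 12 percentage points lower from compound 3 to compound 4 (beyond the scatter) and no change at the digits printed from compound 2 to compound 4 (within the scatter), which places compound 4 level with the ethylamino amide and leaves propoxy as the only group here clear of all the others at this position. Nothing available here explains this drop.

Compound 1 and compound 4 differ in both the atom joined to the carbonyl carbon and the shape of the chain, so the step between them cannot assign the loss to either feature; an isopropoxy group and a propylsulfanyl group on the same carbonyl carbon would separate the two. Going by these compounds, these figures are also single-concentration read-outs rather than potencies, so how far the compounds differ in affinity remains open.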